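The source may report more compounds than this note shows. Statements on the series, on what has been measured and on what is new or still open speak of the compounds shown alone.

Measured in a functional assay on K562 cells (Homo sapiens) for inhibition; on this read-out higher numbers stand for weaker inhibition and lower numbers for stronger inhibition:
- compound 1 `CC(C)CC(=O)OC1C(C(O)CO)OC2OC(C)(C)OC21`: 1000000 nM
- compound 2 `CC1(C)OC2OC(C(O)CO)C(OC(=O)C(C)(C)C)C2O1`: 1500000 nM
- compound 3 `CC(C)C(=O)OC1C(C(O)CO)OC2OC(C)(C)OC21`: 2500000 nM

Compound 1 sits at the low end of these numbers, although only compound 3 stands clearly apart from it. The next molecule is compound 4 `CC(CC(=O)OC1C(C(O)CO)OC2OC(C)(C)OC21)c1ccccc1`, which differs from compound 1 as follows: phenyl in place of methyl on a saturated chain carbon bound to two saturated chain carbons. It carries phenyl in place of methyl on a saturated chain carbon bound to two saturated chain carbons.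

Two measured changes touch the same group. With tert-butyl in place of isobutyl, the data show a 1.5-fold higher number from compound 1 to compound 2 (0.18 log units; within the scatter). With isopropyl in place of isobutyl, they show a 2.5-fold higher number from compound 1 to compound 3 (0.40 log units; beyond the scatter). Within the data shown here, neither adds a ring, so they guide this change only loosely, and the data offer no direct precedent for phenyl.

On these small steps, no change beyond the scatter is expected in this assay. The expected change is a 1.3-fold lower number from compound 1 to compound 4 (0.10 log units; within the scatter). For compound 4, the estimated value is 800000 nM, with an expected range of 300000 nM to 2500000 nM.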

Compound 4, half-maximal inhibitory concentration: 500000 nM
Beside the measured number, compound 4's estimate is 1.6-fold (0.20 log units) above it, within the range that was stated.
By their numbers in this assay, from the lowest: compounds 4, 1, 2 and 3 (each within the scatter of the next, the first and the last beyond it).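

In this assay phenyl in place of methyl on a saturated chain carbon bound to two saturated chain carbons gives a 2.0-fold lower number from compound 1 to compound 4 (0.30 log units; within the scatter) and so adds a six-membered aromatic ring with no shift beyond the scatter. Among these compounds, the earlier compounds varied this part of the molecule only among small saturated chains, so this is the first sign that the place can carry a ring. No measurement here explains the result. As far as these compounds go, whether an amine, a carboxylic acid or a longer chain at the same place would move the number beyond the scatter stays open.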